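Notes on an acyl exchange in the long-chain amide series

The source may hold more compounds than are shown below. What is called first, only, known or untested is meant among the compounds shown, and "the series" means these compounds.

Measured so far:
Compound 1 `C/C=C/C=C/C(=O)N[C@H](C(=O)NCCCCCCCCCCCCCC)[C@@H](C)O` — in a functional assay on SiHa cells (Homo sapiens) for cytotoxicity, read by MTT assay, with a stated time of 48 h (on this read-out lower numbers stand for stronger inhibition and higher numbers for weaker inhibition), compound 1 gives > 200000 nM, which is a limit rather than a number.
Compound 2 `CCCCCCCCCCCCCCCCCCNC(=O)[C@@H](NC(=O)c1ccccc1)[C@@H](C)O` — compound 2 gives 38200 nM.
Compound 3 `CCCCCCCCCCCCCCCCCCNC(=O)[C@@H](NC(=O)c1nccc2ccccc12)[C@@H](C)O` — compound 3 gives 51200 nM.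

Among the compounds with values here, compound 3 holds the higher of the two numbers; compound 2 sits nearest, and the only measured step, a 1.3-fold higher number from compound 2 to compound 3 (0.13 log units; within the scatter), is small. Compound 4 `C/C=C/C=C/C(=O)N[C@H](C(=O)NCCCCCCCCCCCCCCCCCC)[C@@H](C)O` arises from compound 3 by penta-1,3-dien-1-yl in place of isoquinolin-1-yl on a carbonyl carbon. Within the data shown here, no measured step covers this exchange. Compound 1 carries the same penta-1,3-dien-1-yl carbonyl group on a shorter chain and gave only a limit, while compound 3 gave a number. The expectation for compound 4 is therefore a weaker result, with a real chance of a limit: compound 4 is estimated at 130000 nM, between 40000 nM and 400000 nM, an expected step of a 2.5-fold higher number from compound 3 to compound 4 (0.40 log units; beyond the scatter).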

Compound 4, half-maximal inhibitory concentration: > 200000 nM
Compound 4: a limit, no number; the forecaster's own chance of this, stated with the estimate: 45%; middle value at least 1.5-fold (0.18 log units) from the limit.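

Exchange on this carbonyl carbon now gives a step beyond the scatter in this assay, which the isoquinolin-1-yl for phenyl exchange did not: penta-1,3-dien-1-yl in place of isoquinolin-1-yl gives an at least 3.9-fold higher number from compound 3 to compound 4 (0.59 log units; beyond the scatter), and in place of phenyl it gives an at least 5.2-fold higher number from compound 2 to compound 4 (0.71 log units; beyond the scatter). Compound 4 gives > 200000 nM, a limit and not a number. The step from compound 1 to compound 4 cannot be read, with butyl in place of hydrogen on the chain leaving both values as limits: the limit of > 200000 nM in this assay, at which 2 of the 4 values shown sit.

Open, going by these compounds, is whether pentyl, with no double bonds, in place of penta-1,3-dien-1-yl on a carbonyl carbon would return a number. Also open, on these data alone, is what an amine on the phenyl group of compound 2 would do.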